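Replacing dimethylamino with a larger amine on the biaryl ester

This account rests on a few compounds, and the source may have more. Where it says the series, first, only, none or still open, it means among the compounds named here.

Measured compounds:
- Compound 1 `CCOC(=O)c1cccc(-c2ccc(N(C)C)cc2)c1`: 40000 nM
- Compound 2 `CCOC(=O)c1cccc(-c2ccc(OCC)c(N)c2)c1`: 140000 nM

Both compounds were tested in an assay on COS-7 cells for inhibition of patatin-like phospholipase domain-containing protein 2 (Mus musculus); a lower number here means a stronger inhibitor, a higher number a weaker inhibitor. Compound 1 gives 40000 nM, and compound 2 gives 140000 nM. Of the two numbers, compound 1 has the lower one, and the gap to compound 2 is beyond the usual scatter, so compound 1 is the stronger of the pair. Among the measured compounds shown here, no single-point step between these two compounds is recorded, since they differ in more than one place.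

Compound 3 `CCOC(=O)c1cccc(-c2ccc(C(C)N(C)C)cc2)c1` has not yet been measured in this assay. It differs from compound 1 in one place: 1-(dimethylamino)ethyl in place of dimethylamino on an aromatic carbon. The amine is kept, but it now sits on a short carbon chain rather than directly on the ring.

For the measured compounds named here, with no measured step of this kind to lean on, the expectation for compound 3 is a number close to that of compound 1, with a step of no change at the digits printed from compound 1 to compound 3 (within the scatter) that is not expected to go beyond the scatter in either direction. The estimated value for compound 3 in this assay is 40000 nM, in a range from 12000 nM to 130000 nM.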

Compound 3, half-maximal inhibitory concentration: 200000 nM
Compound 3: middle estimate off by 5.0-fold (0.70 log units), on the low side; measured number outside the range, above it.
By their numbers in this assay, from the lowest: compound 1; then compounds 2 and 3 (each within the scatter of the next).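

In this assay, 1-(dimethylamino)ethyl in place of dimethylamino on an aromatic carbon gives a 5.0-fold higher number from compound 1 to compound 3 (0.70 log units; beyond the scatter), so the compound becomes a weaker inhibitor and this position, para to a large group, does respond to the change. The step shows that keeping the amine is not enough to hold the number: the two groups match in hydrogen-bond donors, hydrogen-bond acceptors and net charge, yet they differ in their carbon count and in whether the nitrogen sits directly on the ring. Nothing measured here explains why the number rises, so this remains an observation from a single pair.

The compounds shown leave open whether the short carbon chain itself or the extra methyl branch on it accounts for the step, a question that dimethylaminomethyl, with its unbranched single-carbon link, could help to answer. They also leave open how other amines on the ring, such as pyrrolidine or morpholine, would compare with the dimethylamino group of compound 1.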